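The source may report more compounds than this note shows. Statements on the series, on what has been measured and on what is new or still open speak of the compounds shown alone.

- Compound 1 `COc1ccc(CN2C(=O)/C(=C\c3cc(OC)c(OC)c(OC)c3)c3ccccc32)cc1`: 21400 nM
- Compound 2 `COc1cc(/C=C2/C(=O)N(C)c3ccc(O)cc32)cc(OC)c1OC`: 26300 nM

Both compounds were tested in a functional assay on cells (Cancer cell lines, Homo sapiens) for cytotoxicity, with a stated time of 48 h; a lower number here means a stronger inhibitor of growth, a higher number a weaker inhibitor of growth. Compound 2, at 26300 nM, has the higher of the two numbers, but the gap to compound 1 lies within the usual scatter, so the two cannot be told apart.

Compound 3 `COc1ccc2c(c1)/C(=C\c1cc(OC)c(OC)c(OC)c1)C(=O)N2C` differs from compound 2 in one place: methyl in place of hydrogen on an oxygen on an aromatic ring. This is methyl in place of hydrogen on an oxygen on an aromatic ring, or hydroxy to methoxy. For the measured compounds named here, no measured pair shows this change on its own, so the data offer no direct guide to its size. Going by the values given here, the only hint is that compound 1 and compound 2 differ by more than this single change, yet their values lie within the scatter. The estimated 1.2-fold lower number from compound 2 to compound 3 (0.08 log units; within the scatter) is therefore small, with no clear direction beyond the scatter. For compound 3 the expected value is 22000 nM, within an estimated range of 9000 nM to 55000 nM.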

Compound 3, concentration for total growth inhibition: 28200 nM
Compound 3: the middle estimate sits 1.3-fold (0.11 log units) below what was measured, and the stated range covers the measured number.
By their numbers in this assay, from the lowest: compounds 1, 2 and 3 (each within the scatter of the next).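

In this assay, for the compounds shown here, the step of a 1.1-fold higher number from compound 2 to compound 3 (0.03 log units; within the scatter) is the first reading of methyl in place of hydrogen on an oxygen on an aromatic ring on its own. At this position, hydroxy and methoxy therefore cannot be told apart by this read-out, so the free hydroxy of compound 2 shows no measurable advantage or drawback here. Nothing at hand offers an explanation for this result.

Still open, from the compounds shown here alone, is whether a larger group on this same oxygen, such as a longer chain or one ending in an amine, would move the number beyond the scatter. The compounds shown also leave open what would happen if a group with no oxygen, such as fluorine, took the place of the hydroxy or methoxy.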